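The source may hold more compounds than are shown below. What is called first, only, known or untested is meant among the compounds shown, and "the series" means these compounds.

Measured compounds:
Compound 1, `CC(=O)C[C@H]1O[C@@H](On2cc(CN3C(=O)/C(=N\Nc4ccc(Br)cc4)c4ccccc43)nn2)[C@H](OC(C)=O)[C@@H](OC(C)=O)[C@@H]1OC(C)=O`: 116000 nM
Compound 2, `CC(=O)C[C@H]1O[C@@H](On2cc(CN3C(=O)/C(=N\Nc4ccccc4)c4ccccc43)nn2)[C@H](OC(C)=O)[C@@H](OC(C)=O)[C@H]1OC(C)=O`: 65200 nM

In an ADME assay on Vero cells (Chlorocebus sabaeus) for cytotoxicity, read by fluorescence and resazurin assay, with a stated time of 3 days (on this read-out lower numbers stand for higher toxicity in this test and higher numbers for lower toxicity in this test), compound 2 gives 65200 nM, the lowest of the two numbers recorded. Its nearest neighbour is compound 1, whose number in this assay is 116000 nM, a gap that lies within the usual scatter, so the two compounds cannot be told apart on this read-out. Compound 3, `CC(=O)C[C@H]1O[C@@H](On2cc(CN3C(=O)/C(=N\Nc4ccc(Br)cc4)c4ccccc43)nn2)[C@H](OC(C)=O)[C@@H](OC(C)=O)[C@H]1OC(C)=O`, has not yet been measured. It differs from compound 2 in one place: bromo in place of hydrogen on an aromatic carbon. Compound 1 also carries a 4-bromophenyl group, and since compound 1 and compound 2 sit within the scatter of each other, there is no sign so far that this group moves the number. Compound 3 is therefore expected to show a step of a 1.2-fold higher number from compound 2 to compound 3 (0.09 log units; within the scatter) from compound 2, which is no change beyond the scatter. Compound 3 is estimated to give 80000 nM in this assay, with a range from 40000 nM to 160000 nM.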

Compound 3, half-maximal cytotoxic concentration: 83400 nM
The estimate for compound 3 lay 1.0-fold (0.02 log units) below the measured number; the range from low to high includes it.
By their numbers in this assay, from the lowest: compounds 2, 3 and 1 (each within the scatter of the next).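

In this assay, the change from hydrogen to bromo on the aromatic carbon can now be read on its own, which the earlier pair did not allow, since compound 1 and compound 2 differ in more than one place. The result is a step of a 1.3-fold higher number from compound 2 to compound 3 (0.11 log units; within the scatter), so phenyl and 4-bromophenyl cannot be told apart on this read-out. The step of a 1.4-fold lower number from compound 1 to compound 3 (0.14 log units; within the scatter) is also no change beyond the scatter, and it can be read for one stereocentre alone: the fact that compounds 1 and 3 differ only in the configuration as drawn

The compounds shown leave open whether a different group in place of the bromo, such as an amine or a carboxylic acid, would move the number beyond the scatter. They also leave open whether the other stereocentres of the shared core matter in this test.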